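Urea series at one concentration: effect of trifluoromethyl removal

A few compounds are considered here, and "the series" means these few. Any claim that something is new, unique, unknown or untested is made for them only; others in the source may bear on it.

Of the compounds shown here, two of the shared core have been measured. In a functional assay on NCI-H322M cells (Homo sapiens) for inhibition, read by sulforhodamine B assay, with a stated time of 48 h, tested at 0.01 uM (on this read-out higher numbers stand for a weaker effect at the one concentration tested and lower numbers for a stronger effect), compound 1 `O=C(Nc1cccc(-n2cc(-c3ccncc3)c(-c3cc(O)cc(Cl)c3)n2)c1)Nc1ccc(Cl)c(Cl)c1` gives 52%. In this assay compound 2 `COc1cc(Cl)cc(-c2nn(-c3cccc(NC(=O)Nc4cc(C(F)(F)F)cc(C(F)(F)F)c4)c3)cc2-c2ccncc2)c1` gives 100%, the highest of the two numbers; its nearest neighbour is compound 1, lower by a gap that lies beyond the scatter. Among the compounds with values here, no pair of measured compounds differs in one place only, so no single step is known.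

Compound 3 `COc1cc(Cl)cc(-c2nn(-c3cccc(NC(=O)Nc4cccc(C(F)(F)F)c4)c3)cc2-c2ccncc2)c1` is not yet measured. It differs from compound 2 by hydrogen in place of trifluoromethyl on an aromatic carbon. Within the data shown here, whether this change alters the read-out is open; the only guide is that compound 2 gives 100%, which leaves room for movement towards a stronger effect but little for a weaker one. For compound 3 the read-out in this assay is expected near 85%, within 55% to 105%. The estimated step of a number 15 percentage points lower from compound 2 to compound 3 (beyond the scatter) is modest, toward a stronger effect, and may not exceed the scatter.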

Compound 3, a percentage reported as activity, at one concentration (the size of the read-out at that concentration, not a potency): 99%
Compound 3: the middle estimate sits 14 percentage points below what was measured, and the stated range covers the measured number.
By their numbers in this assay, from the lowest: compound 1; then compounds 3 and 2 (each within the scatter of the next).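

In this assay the series now has its first change in a single place, hydrogen in place of trifluoromethyl on an aromatic carbon, and it gives a number 1 percentage points lower from compound 2 to compound 3 (within the scatter) in the read-out. Compound 2 and compound 3 therefore cannot be told apart at this one concentration, so this trifluoromethyl group shows no measurable contribution here, and that finding is limited to this read-out. Nothing available on these compounds accounts for this result.

Still open, going by these compounds, is whether an amine or a carboxylic acid in this place, or removal of the remaining trifluoromethyl, would move the read-out. Compound 1 differs from compound 2 in more than one place, so the gap between their numbers cannot yet be assigned to any single group.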